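A few compounds are considered here, and "the series" means these few. Any claim that something is new, unique, unknown or untested is made for them only; others in the source may bear on it.

Compound 1 `C=CC1=C(C(=O)NCc2ccccc2)C(c2ccc(OC)cc2)OC1`: in a functional assay on A549 cells (Homo sapiens) for cytotoxicity, read by MTT assay, with a stated time of 24 h (a higher number here means a weaker inhibitor, a lower number a stronger inhibitor), compound 1 gives > 100000 nM, which is a limit of the assay rather than a number.
Compound 2 `C=CC1=C(C(=O)Nc2ccccc2)C(c2ccc(Cl)c(Cl)c2)OC1`: in this assay compound 2 gives > 100000 nM, again a limit.
Compound 3 `C=CC1=C(C(=O)Nc2ccc(OCC)cc2)C(c2ccc(OC)cc2)OC1`: in this assay compound 3 gives 17600 nM.

Among the measured compounds shown here, compound 3 thus holds the only measured number; the other two sit at the limit of > 100000 nM in this assay, at which 2 of the 3 values shown sit. Compound 4 `C=CC1=C(C(=O)Nc2ccccc2)C(c2ccc(OC)cc2)OC1` differs from it by hydrogen in place of ethoxy on an aromatic carbon. For the measured compounds named here, the one measured step that touches this part of the molecule, an at least 5.6-fold lower number from compound 1 to compound 3 (0.75 log units; beyond the scatter), shows that the 4-ethoxyphenyl accompanied the only number below the limit. Taking the ethoxy away may give back part of that gain, so a weaker result is expected for compound 4, a 3.4-fold higher number from compound 3 to compound 4 (0.53 log units; beyond the scatter), with a real chance of another limit. Compound 4 is estimated at 60000 nM, expected between 20000 nM and 150000 nM.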

Compound 4, half-maximal inhibitory concentration: > 100000 nM
Compound 4 was reported as a limit (the forecaster's own chance of this, stated with the estimate: 45%); middle value at least 1.6-fold (0.22 log units) from the limit.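

Hydrogen in place of ethoxy brings an at least 5.6-fold higher number from compound 3 to compound 4 (0.75 log units; beyond the scatter), so the phenyl on the amide nitrogen does not by itself give the number seen for compound 3; the ethoxy is what separates them. The steps from compound 1 and from compound 2 to compound 4 cannot be read, since both ends of each are limits. Compound 3 remains the only compound with a number: the limit of > 100000 nM in this assay, at which 3 of the 4 values shown sit.

Going by these compounds, whether a methoxy, an amine or a longer chain such as butoxy at the same place would also give a number stays open. So does whether ethoxy would act alike with the 3,4-dichlorophenyl of compound 2.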